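A few compounds are considered here, and "the series" means these few. Any claim that something is new, unique, unknown or untested is made for them only; others in the source may bear on it.

Measured so far in a functional assay on KG-1 cells (Homo sapiens) for cytotoxicity, read by luminescence and CellTiter-Glo, with a stated time of 3 days; a lower number here means a stronger inhibitor, a higher number a weaker inhibitor:
Compound 1 `COc1ccc(O)c(C(=O)Nc2ccc(C#N)cc2)c1`: > 10000 nM (a limit of the assay)
Compound 2 `Cc1ccc(C(=O)Nc2ccc(C#N)cc2)c(O)c1`: 2560 nM

Only one of these two results is a true number. Going by the values given here, compound 2 stands at 2560 nM, and no other compound has yet given a measured figure to set beside it. Compound 1 reads > 10000 nM, which is a limit and not a number. Among the compounds with values here, no pair of measured compounds differs in one place only, so the data offer no direct guide to the size of a single change.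

The next compound is compound 3 `N#Cc1ccc(NC(=O)c2ccc(-c3ccncc3)cc2O)cc1`. It carries pyridin-4-yl in place of methyl on an aromatic carbon, meta to a hydroxy group and para to a large group (pyridin-4-yl in place of methyl on an aromatic carbon). Within the data shown here, with no measured step to lean on, a moderate gain is expected in this assay, though the uncertainty is wide and a result within the scatter would not surprise. The expected change is a step of a 3.2-fold lower number from compound 2 to compound 3 (0.51 log units; beyond the scatter). For compound 3 the estimated value is 800 nM, with an expected range from 120 nM to 5000 nM.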

Compound 3, half-maximal inhibitory concentration: 8840 nM
The estimate for compound 3 lay 11-fold (1.04 log units) below the measured number; the whole stated range lies below it.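

In this assay, pyridin-4-yl in place of methyl on an aromatic carbon, meta to a hydroxy group and para to a large group, gives a 3.5-fold higher number from compound 2 to compound 3 (0.54 log units; beyond the scatter). Going by these compounds alone, this is the first comparison that differs in one place, and it shows that at this position the six-membered aromatic ring weakens the compound relative to methyl, although compound 3 still gives a true number. Compound 1 holds the one limit in the series, and that limit leaves little readable room above compound 3: the limit of > 10000 nM in this assay, at which 1 of the 3 values shown sits.

The compounds shown leave open whether the weakening goes with the ring as a whole or with its nitrogen, since a plain phenyl on the same carbon would be needed to separate the two. They also leave open how small groups behave at this position, such as a chlorine, an amine or an ethyl chain, and so whether methyl is close to the best that this carbon allows or whether a group of another kind would bring the number down from that of compound 2.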